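A few compounds are considered here, and "the series" means these few. Any claim that something is new, unique, unknown or untested is made for them only; others in the source may bear on it.

Series notes. Two compounds carry numbers in a functional assay on HepG2 cells (Homo sapiens) for cytotoxicity; a higher number here means that more compound is tolerated, a lower number that less compound is tolerated. Compound 1 `Cn1c(CCC2CCCO2)nc2cc(Cl)c(Cl)cc21` gives 56000 nM in this assay; compound 2 `Cc1ccc(S(=O)(=O)n2c(N3C(=O)c4ccccc4C3=O)nc3cc(Cl)c(Cl)cc32)cc1` gives 122000 nM in this assay. Compound 1 thus stands at the lowest of the two numbers, and the gap to compound 2 lies beyond the scatter, so less of compound 1 is tolerated than of compound 2. Compound 3 `CCCc1nc2cc(Cl)c(Cl)cc2n1C` is not yet measured. It differs from compound 1 in one place: methyl in place of oxolan-2-yl on a saturated chain carbon, two bonds along the chain from an aromatic carbon; the same difference, cut one bond further out, reads (oxolan-2-yl)methyl to ethyl. Among the compounds with values here, no measured pair shows this change, so its effect on the half-maximal cytotoxic concentration in this assay is unknown. With nothing to support a shift in either direction, the step is expected to stay within the scatter, a 1.1-fold higher number from compound 1 to compound 3 (0.03 log units; within the scatter). For compound 3 the estimate in this assay is 60000 nM, with a range from 25000 nM to 150000 nM.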

Compound 3, half-maximal cytotoxic concentration: 24600 nM
Beside the measured number, compound 3's estimate is 2.4-fold (0.39 log units) above it, and the stated range ends above it.
By their numbers in this assay, from the lowest: compound 3; then compound 1; then compound 2.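

In this assay, methyl in place of oxolan-2-yl on a saturated chain carbon, two bonds along the chain from an aromatic carbon, gives a 2.3-fold lower number from compound 1 to compound 3 (0.36 log units; beyond the scatter), so less of the methyl compound is tolerated. Within the data shown here, this is the first single-place step, and it shows that the group carried at this position can move the half-maximal cytotoxic concentration beyond the scatter, though the step is modest. No measurement offered here explains the shift.

From the compounds shown here alone, with a single pair at this position, it remains open whether the number follows the ring, the oxygen or the size of the group. Going by these compounds, a methoxy group, an amine or a longer chain in the same place could separate these readings, and whether the step carries over to another core also remains open.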